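Adding a Phenyl Group to the Core of Compound 1

The source may report more compounds than this note shows. Statements on the series, on what has been measured and on what is new or still open speak of the compounds shown alone.

Compound 1 `O=C(O)c1cc(-n2c(-c3ccccc3)cc3c2CCCC3)ccc1O` gives >= 60% in a functional assay on the whole organism (strain Wistar) for inhibition, with Rattus norvegicus as the target, read by paw edema, with stated times of 30 min and 3 h, at a dose of 200 mg/kg by the oral route; on this read-out lower numbers stand for less inhibition and higher numbers for more inhibition at the one dose given (going by the name of the read-out).
Compound 2 `COc1ccccc1-c1cc2c(n1-c1ccc(O)c(C(=O)O)c1)CCCC2` gives 50% in this assay.

Compound 1 stands at the limit of >= 60% in this assay, at which 1 of the 2 values shown sits; its value is a limit, not a number. Compound 3 `O=C(O)c1cc(-n2c3c(c(-c4ccccc4)c2-c2ccccc2)CCCC3)ccc1O` differs from compound 1 by phenyl in place of hydrogen on an aromatic carbon. For the measured compounds named here, the only measured step, a number at least 10 percentage points lower from compound 1 to compound 2 (that floor lies within the scatter), concerns a different change at another place, so no measured step bears directly on this one, and no direction beyond the scatter can be read from it. Compound 3 is therefore expected near 55%, within 35% to 70%. That would mean an expected step of a number at least 5 percentage points lower from compound 1 to compound 3 (that floor lies within the scatter).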

Compound 3, a percentage reported as inhibition, in the whole organism at one dose (the size of the read-out at that dose, not a potency): 30%
Compound 3: middle estimate off by 25 percentage points, on the high side; measured number below the stated range.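

Putting a phenyl group on this aromatic carbon of the core, two ring bonds from the ring nitrogen, gives in this assay a number at least 30 percentage points lower from compound 1 to compound 3 (beyond the scatter). Unlike the methoxy change at another place, whose floor lies within the scatter, this change shows that the position does not accept every group without a loss of inhibition. This step is a floor, as compound 1 carries a limit and not a number: the limit of >= 60% in this assay, at which 1 of the 3 values shown sits.

The compounds shown leave open how a methyl group or an amine at this position would read out. With a single group tested here, they also cannot tell why phenyl lowers the inhibition.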